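The source may hold more compounds than are shown below. What is called first, only, known or untested is meant among the compounds shown, and "the series" means these compounds.

Of the compounds shown here, three from this study have numbers so far, all from a functional assay on BGC-823 cells (Homo sapiens) for antiproliferative activity, read by MTT assay, tested at 5 uM; a lower number here means a weaker effect, a higher number a stronger effect of the compound at the concentration tested. Compound 1 `COc1cc(C(=O)N/N=C/c2ccccc2C(F)(F)F)cc(OC)c1OC` gives 35.6%, and compound 3 `COc1cccc(/C=N/NC(=O)c2cc(OC)c(OC)c(OC)c2)c1OC` gives 14.2%. Compound 2 `COc1ccc(C2OC(c3cc(OC)c(OC)c(OC)c3)=NN2C(C)=O)c(OC)c1`, which carries its two aryl groups on a five-membered non-aromatic ring with 2 nitrogen and 1 oxygen rather than on an open hydrazone chain, gives -3.1%. Among these three numbers compound 2 stands lowest: compound 3 lies above it by a margin beyond the usual scatter, and compound 1 lies higher still. None of the three pairs differs in only one place, so no single change can be credited with any of these gaps.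

Compound 4 `COc1cc(C2=NN(C(C)=O)C(c3ccc(C(F)(F)F)cc3)O2)cc(OC)c1OC` keeps the ring of compound 2 and changes one group on it: 4-(trifluoromethyl)phenyl in place of 2,4-dimethoxyphenyl on a saturated ring carbon. Within the data shown here, no measured pair shows what such a swap does on this ring, and the only trifluoromethyl-bearing compound with a number, compound 1, has a different backbone. The step from compound 2 to compound 4 is therefore expected to be small, perhaps upward, and may not exceed the scatter; the expected step is a number 11.1 percentage points higher from compound 2 to compound 4 (beyond the scatter). Compound 4 is estimated to give 8% in this assay, within a range from -12% to 30%.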

Compound 4, a percentage reported as inhibition, at one concentration (the size of the read-out at that concentration, not a potency): 3.4%
The estimate for compound 4 lay 4.6 percentage points above the measured number; low and high end bracket the measured number.
By their numbers in this assay, from the lowest: compounds 2 and 4 (each within the scatter of the next); then compound 3; then compound 1.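

Among these compounds, putting 4-(trifluoromethyl)phenyl in place of 2,4-dimethoxyphenyl on this saturated ring carbon gives a number 6.5 percentage points higher from compound 2 to compound 4 (within the scatter) in this assay, the only direct reading so far of a change at this position. The leaving group counts two hydrogen-bond acceptors and the entering group none, yet on this one pair that exchange produces no difference that can be told apart from repeat scatter, with compound 2 at -3.1% and compound 4 at 3.4% at the single concentration tested. Nothing available explains why the swap leaves the read-out within the scatter, and a single pair establishes no trend for this position.

Still open, as far as these compounds go, is whether a quite different group on this ring carbon, such as a phenyl ring carrying an amine or a carboxylic acid, or a plain alkyl chain in place of the aromatic ring, would shift the number beyond the scatter. Equally open, from the compounds shown here alone, is what a longer acyl chain would do in place of the acetyl group on the same ring.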